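The source may report more compounds than this note shows. Statements on the series, on what has been measured and on what is new or still open speak of the compounds shown alone.

Compound 1 has the structure `CN1CCN(c2ccc(Nc3ncc4c(n3)N(C3CCCC3)CC(=O)N4)nc2)CC1`. In a functional assay on MDA-MB-231 cells (Homo sapiens) for inhibition, read by MTT assay, with a stated time of 48 h (on this read-out lower numbers stand for stronger inhibition and higher numbers for weaker inhibition), compound 1 gives > 30000 nM, and this is a limit of the assay rather than a measured number. Two close relatives are known. Compound 2, `CC1CCN(c2ccc(Nc3ncc4c(n3)N(C3CCCC3)CC(=O)N4)nc2)CC1`, carries 4-methylpiperidin-1-yl in place of 4-methylpiperazin-1-yl on an aromatic carbon, and in this assay compound 2 gives > 30000 nM, again a limit. Compound 3, `O=C1CN(C2CCCC2)c2nc(Nc3ccc(N4CCNCC4)cn3)ncc2N1`, has hydrogen in place of methyl on an amine nitrogen in a ring, and in this assay compound 3 gives > 30000 nM, also a limit. The steps a step that the two limits leave unreadable from compound 1 to compound 2, a step that the two limits leave unreadable from compound 1 to compound 3 and a step that the two limits leave unreadable from compound 2 to compound 3 therefore cannot be sized, because all three values sit at the limit of > 30000 nM in this assay, at which 3 of the 3 values shown sit.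

Compound 4, `CN1CCN(c2ccc(Nc3ncc4c(n3)N(C3CCCC3)CC(=O)N4C)nc2)CC1`, is the compound still to be measured. It differs from compound 1 by methyl in place of hydrogen on an amide-type nitrogen in a ring. Among the compounds with values here, none of the measured steps touches this amide-type nitrogen in a ring; each of them alters the group on the aromatic carbon or the amine nitrogen in a ring, and each ended at the limit. Nothing in these values points to a gain in potency.

Compound 4 is therefore expected to remain near the limit, estimated at 40000 nM with a range from 10000 nM to 150000 nM. The step that the limit leaves unreadable from compound 1 to compound 4 is expected to be none beyond the scatter.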

Compound 4, half-maximal inhibitory concentration: 23700 nM
Compound 4: the middle estimate sits 1.7-fold (0.23 log units) above what was measured; the range from low to high includes it.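

Methyl on the amide-type nitrogen in a ring is the only change shown at this position, and it is also the only change that brings a compound off the limit and onto a readable number. In this assay the change gives an at least 1.2-fold lower number from compound 1 to compound 4 (0.10 log units; that floor lies within the scatter); this is only a floor, so the true step may be larger, or it may be no more than ordinary scatter. The steps among compounds 1, 2 and 3 cannot be read, and this step can be given only as a floor, because compound 1 stands at the same limit as those relatives: the limit of > 30000 nM in this assay, at which 3 of the 4 values shown sit.

The compounds shown leave open how an ethyl group, or a longer chain ending in an amine or a carboxylic acid, would read on this nitrogen in this assay. They also leave open whether the same methyl would bring a readable number when the group on the aromatic carbon is 4-methylpiperidin-1-yl or piperazin-1-yl instead of 4-methylpiperazin-1-yl.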